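Chloro-to-methyl swap on the ester series, compound 4

This account rests on a few compounds, and the source may have more. Where it says the series, first, only, none or still open, it means among the compounds named here.

Compound 1 `CC(=O)c1nn(-c2ccc(C)cc2)/c(=N/c2nc(-c3c(C)n(C)n(-c4ccccc4)c3=O)cs2)s1` gives 31700 nM in a functional assay on HepG2 cells (Homo sapiens) for cytotoxicity, read by sulforhodamine B assay, with a stated time of 72 h; a higher number here means a weaker inhibitor, a lower number a stronger inhibitor.
Compound 2 `CCOC(=O)c1nn(-c2ccccc2)/c(=N/c2nc(-c3c(C)n(C)n(-c4ccccc4)c3=O)cs2)s1` gives > 100000 nM in this assay, a limit and not a number.
Compound 3 `CCOC(=O)c1nn(-c2ccc(Cl)cc2)/c(=N/c2nc(-c3c(C)n(C)n(-c4ccccc4)c3=O)cs2)s1` gives > 100000 nM in this assay, again a limit rather than a number.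

Compound 3 therefore stands at the edge of what this assay can report, as does compound 2; see (the limit of > 100000 nM in this assay, at which 2 of the 3 values shown sit). For the measured compounds named here, the one measured step, a step that the two limits leave unreadable from compound 2 to compound 3, runs between two limits and its size cannot be read. Going by the values given here, compound 1 differs from compound 3 in two places, so no single step to it is drawn; its value merely shows that a number inside the range of this assay can be reached within the shared core.

Compound 4 `CCOC(=O)c1nn(-c2ccc(C)cc2)/c(=N/c2nc(-c3c(C)n(C)n(-c4ccccc4)c3=O)cs2)s1` differs from compound 3 by methyl in place of chloro on an aromatic carbon. Among the compounds with values here, no measured step speaks to this change, and the only step nearby is unreadable. Compound 4 is expected to land near the limit again, with the estimated step of an at least 1.2-fold lower number from compound 3 to compound 4 (0.09 log units; that floor lies within the scatter) taken as no change beyond the scatter. The estimate for compound 4 is 80000 nM, with a range from 30000 nM to 200000 nM.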

Compound 4, half-maximal inhibitory concentration: > 100000 nM
Compound 4: no number, only a limit; the forecaster's own chance of this, stated with the estimate: 60%; at least 1.2-fold (0.09 log units) between middle value and limit.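

Compound 4 gives > 100000 nM in this assay, a limit and not a number, so with hydrogen, chloro or methyl on this aromatic carbon the ethoxy carbonyl compounds all sit at the same edge of the read-out: the limit of > 100000 nM in this assay, at which 3 of the 4 values shown sit.

The steps among compound 2, compound 3 and compound 4 cannot be read, as each runs between two limits. For the compounds shown here, the one readable step, with the 4-methylphenyl group held fixed, is ethoxy in place of methyl on the carbonyl carbon, and it gives an at least 3.1-fold higher number from compound 1 to compound 4 (0.49 log units; beyond the scatter).

Still open, going by these compounds, is whether 4-chlorophenyl in place of 4-methylphenyl moves the value when methyl sits on the carbonyl carbon. Also open, on these data alone, is whether a carboxylic acid or an amide in place of the ethyl ester brings a number back inside the range of this assay.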